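Swapping a Side Chain on the Shared Core

The source may report more compounds than this note shows. Statements on the series, on what has been measured and on what is new or still open speak of the compounds shown alone.

Of the compounds shown here, three sharing one core have been read so far in a physicochemical assay for lipophilicity, at pH 7.4 (on this read-out higher numbers stand for higher lipophilicity and lower numbers for lower lipophilicity), and they span a narrow band. Compound 2 (`COCCOc1ccc2c(c1)C=CN(C)C(=O)[C@@H]2C`) gives 4 and stands highest of the three, beyond the scatter from both others. Compound 3 (`CC1C(=O)N(C)C=Cc2cc(OCC(C)(C)O)ccc21`) comes in at 3.6 and compound 1 (`COc1cc2c(cc1OC)[C@@H](C)C(=O)N(C)C=C2`) at 3.4 within the scatter of each other. Compound 3 carries a hydroxyl on its chain and compound 1 carries none, so that feature alone does not sort the three values.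

The unmeasured compound 4 (`C[C@H]1C(=O)N(C)C=Cc2cc(C(O)CO)ccc21`) has 1,2-dihydroxyethyl in place of 2-methoxyethoxy on an aromatic carbon and its reading is still to come. Among the compounds with values here, no measured pair differs in one place only, so no direct step is available in this assay to scale this change. The expectation starts from compound 2 at 4 and rests on the hydrogen-bond donors that 1,2-dihydroxyethyl brings and 2-methoxyethoxy lacks. The estimated step is a number 1.00 log units lower from compound 2 to compound 4 (beyond the scatter) and it is expected to point downward, beyond the scatter. For compound 4 the estimate is 3 with an expected range from 2.5 to 3.5 in repeat measurements.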

Compound 4, distribution coefficient: 1.1
Compound 4: middle estimate off by 1.90 log units, on the high side, and the stated range ends above it.
By their numbers in this assay, from the lowest: compound 4; then compounds 1 and 3 (each within the scatter of the next); then compound 2.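

Placing 1,2-dihydroxyethyl in place of 2-methoxyethoxy on this aromatic carbon, meta to a fused ring and para to a fused ring, gives the first step in this assay between compounds that differ in one place only, and that step is large: a number 2.90 log units lower from compound 2 to compound 4 (beyond the scatter). The two chains differ little in the counts available, with 4 heavy atoms entering against 5 leaving, 2 hydrogen-bond acceptors on each and no net charge on either, while the entering chain has 2 hydrogen-bond donors and the leaving chain has 0. Nothing available here accounts for the size of this step, so it stands as a measured difference for this one pair.

With a single pair, the step cannot be divided between the two hydroxyl groups of the entering chain and the loss of the ether oxygen attached to the aromatic carbon. Going by these compounds, how far a 2-hydroxyethoxy chain, a 2-hydroxyethyl chain or a single methoxy group at this position would fall along the same step remains open, as does whether the same exchange would give a similar step elsewhere on the shared core.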